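A Bromophenyl Group Replaces Fluorobenzyl on Compound 3

The source may hold more compounds than are shown below. What is called first, only, known or untested is meant among the compounds shown, and "the series" means these compounds.

In a functional assay on DU-145 cells (Homo sapiens) for inhibition, read by trypan blue exclusion, with a stated time of 96 h (on this read-out lower numbers stand for stronger inhibition of growth and higher numbers for weaker inhibition of growth), compound 3 `O=C(/C(=C\c1ccccc1OCc1ccccc1)S(=O)(=O)Cc1ccc(F)cc1)c1ccc(Cl)cc1` gives 10000 nM and sits in the middle of the three measured compounds, with compound 1 `O=C(/C(=C\c1ccccc1OCc1ccccc1)S(=O)(=O)c1ccc(F)cc1)c1ccc(Cl)cc1` at 1000 nM and compound 2 `O=C(/C(=C\c1ccccc1F)S(=O)(=O)c1ccc(Br)cc1)c1ccc(Cl)cc1` at 25000 nM on either side. Compound 4 `O=C(/C(=C\c1ccccc1OCc1ccccc1)S(=O)(=O)c1ccc(Br)cc1)c1ccc(Cl)cc1` carries 4-bromophenyl in place of 4-fluorobenzyl on a sulfonyl sulfur, a difference counted as 4-bromophenyl in place of 4-fluorobenzyl on a sulfonyl sulfur and still unmeasured. For the measured compounds named here, the one measured step that bears on it is a 10-fold higher number from compound 1 to compound 3 (1.00 log units; beyond the scatter) with 4-fluorobenzyl in place of 4-fluorophenyl on a sulfonyl sulfur. Compound 4 again has a substituted phenyl there, so that step, run backwards, points to a lower number of similar size. Compound 2 shares the 4-bromophenyl but differs elsewhere, so it offers little guidance. The expected change is a 6.7-fold lower number from compound 3 to compound 4 (0.82 log units; beyond the scatter) in this assay overall. For compound 4 the estimate is 1500 nM with an expected range from 400 nM to 6000 nM.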

Compound 4, concentration for 50% growth inhibition: 1000 nM
The estimate for compound 4 lay 1.5-fold (0.18 log units) above the measured number; the measured number falls inside the stated range.
By their numbers in this assay, from the lowest: compounds 1 and 4 (each within the scatter of the next); then compound 3; then compound 2.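

With bromo in place of fluoro on an aromatic carbon, the sulfonyl phenyl shows no change at the digits printed from compound 1 to compound 4 (within the scatter) and so tolerates either halogen. The gain of a 10-fold lower number from compound 3 to compound 4 (1.00 log units; beyond the scatter) therefore tracks the change from benzyl to phenyl on the sulfonyl sulfur, not the halogen. At the other changed place, benzyloxy in place of fluoro gives a 25-fold lower number from compound 2 to compound 4 (1.40 log units; beyond the scatter) and is the largest step here. No measurement offered here explains these steps. From the compounds shown here alone, whether a longer chain on the sulfonyl sulfur, or an amine in place of the halogen, would keep this growth inhibition remains open.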